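Swapping the Pendant Ring on the Shared Core

A few compounds are considered here, and "the series" means these few. Any claim that something is new, unique, unknown or untested is made for them only; others in the source may bear on it.

Compounds measured so far:
- compound 1, `C[C@@H](O[C@H]1CN2C(=O)C=C(c3ccc(CO)cc3)CC2[C@@H]1c1ccc(F)cc1)c1cc(C(F)(F)F)cc(C(F)(F)F)c1`: 23 nM
- compound 2, `C[C@@H](O[C@H]1CN2C(=O)C=C(c3cnn(Cc4ccccc4)c3)CC2[C@@H]1c1ccc(F)cc1)c1cc(C(F)(F)F)cc(C(F)(F)F)c1`: 66 nM

Both compounds were tested in an assay on CHO cells for displacement of a labelled ligand from Substance-P receptor (Homo sapiens), in the presence of a further agent that is not named here; a higher number here means a weaker inhibitor, a lower number a stronger inhibitor. Among the measured compounds shown here, compound 2 stands at the higher of the two numbers, so it is the weaker inhibitor of the pair, and its only neighbour is compound 1 at 23 nM. For the measured compounds named here, the single step that connects them, a 2.9-fold higher number from compound 1 to compound 2 (0.46 log units; beyond the scatter), is modest but lies beyond the scatter of the assay.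

Compound 3, `C[C@@H](O[C@H]1CN2C(=O)C=C(C3CCOCC3)CC2[C@@H]1c1ccc(F)cc1)c1cc(C(F)(F)F)cc(C(F)(F)F)c1`, has not been measured. It differs from compound 2 in one place: oxan-4-yl in place of 1-benzyl-1H-pyrazol-4-yl on a double-bonded ring carbon. Going by the values given here, this replacement is much larger than the one between compound 1 and compound 2, since an aromatic two-ring group gives way to a small saturated ring, and no measured step covers anything like it. Among the compounds with values here, the only guidance is that the position itself tolerates a change of substituent with a modest shift, as the step from compound 1 to compound 2 shows. The estimate for compound 3 therefore stays near compound 2, as a 1.1-fold higher number from compound 2 to compound 3 (0.03 log units; within the scatter), with a wide range: compound 3 is expected to give about 70 nM, between 15 nM and 400 nM.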

Compound 3, half-maximal inhibitory concentration: 3.2 nM
Compound 3: middle estimate off by 22-fold (1.34 log units), on the high side; the measured number lies below the stated range.
By their numbers in this assay, from the lowest: compound 3; then compound 1; then compound 2.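

In this assay, the position on the double-bonded ring carbon turns out not to need an aromatic ring: oxan-4-yl, a non-aromatic ring, gives the strongest inhibitor of the three, with a 21-fold lower number from compound 2 to compound 3 (1.31 log units; beyond the scatter) and a 7.2-fold lower number from compound 1 to compound 3 (0.86 log units; beyond the scatter) both standing beyond the scatter. Among the compounds shown here, the earlier pair compared only two groups containing aromatic rings and showed a modest shift, whereas this result shows that the choice of group here can move the number much further than that step suggested. Nothing available here explains why the number falls so far.

The change from compound 2 to compound 3 alters several things at once, including ring type, ring count and heavy-atom count, so these three compounds cannot show which of them matters, or whether the ring oxygen of oxan-4-yl plays any part. On these data alone, a cyclohexyl ring, with carbon in place of that oxygen, or a piperidin-4-yl ring, with nitrogen there, would be the closest comparisons, and how either would fare on the shared core remains open.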